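This account rests on a few compounds, and the source may have more. Where it says the series, first, only, none or still open, it means among the compounds named here.

Three compounds have so far been measured in a functional assay on BXPC-3 cells (Homo sapiens) for antiproliferative activity, read by sulforhodamine B assay, with a stated time of 72 h; on this read-out lower numbers stand for stronger inhibition and higher numbers for weaker inhibition:

Compound 1, `CN(CCNCc1cn(-c2ccccc2)nn1)CCNc1ccnc2cc(Cl)ccc12`: 10000 nM
Compound 2, `CN(CCNCc1cn(-c2ccc(F)cc2)nn1)CCNc1ccnc2cc(Cl)ccc12`: 12000 nM
Compound 3, `CN(CCNCc1cn(-c2cccc(Cl)c2)nn1)CCNc1ccnc2cc(Cl)ccc12`: 12000 nM

All three share a common core and differ only in the aryl group carried on the aromatic nitrogen of the five-membered ring. In this assay compound 2 gives 12000 nM, which puts it level with compound 3 and together with it at the top of the three numbers; the measured step is a 1.2-fold higher number from compound 1 to compound 2 (0.08 log units; within the scatter), so all three sit within the usual scatter of one another.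

Compound 4, `CN(CCNCc1cn(-c2ccccc2Cl)nn1)CCNc1ccnc2cc(Cl)ccc12`, is the next step from compound 2. The change is 2-chlorophenyl in place of 4-fluorophenyl on an aromatic nitrogen.

Going by the values given here, three measured steps bear on it. Adding fluoro to the phenyl gave a 1.2-fold higher number from compound 1 to compound 2 (0.08 log units; within the scatter); adding chloro gave a 1.2-fold higher number from compound 1 to compound 3 (0.08 log units; within the scatter); and swapping one substituted phenyl for another gave no change at the digits printed from compound 2 to compound 3 (within the scatter). Among the compounds with values here, none of these moved the number beyond the scatter, and no measured step in this set distinguishes where on the phenyl a halogen sits. The step to compound 4 is therefore expected to be no change at the digits printed from compound 2 to compound 4 (within the scatter), with no change beyond the scatter in either direction.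

On that basis compound 4 is estimated at 12000 nM, in a range from 6000 nM to 25000 nM.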

Compound 4, half-maximal inhibitory concentration: 11000 nM
For compound 4 the middle estimate is 1.1-fold (0.04 log units) above the measured one; low and high end bracket the measured number.
By their numbers in this assay, from the lowest: compounds 1, 4, 2 and 3 (each within the scatter of the next).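

Compound 4 puts the halogen in a new place, as the 2-chlorophenyl group on the aromatic nitrogen, and in this assay this changes nothing beyond the scatter (a 1.1-fold lower number from compound 2 to compound 4 (0.04 log units; within the scatter); a 1.1-fold lower number from compound 3 to compound 4 (0.04 log units; within the scatter); a 1.1-fold higher number from compound 1 to compound 4 (0.04 log units; within the scatter)). The earlier compounds shown here covered only the 4-fluorophenyl and 3-chlorophenyl groups and the plain phenyl, so the 2-chlorophenyl group extends the flat picture: across these four compounds, neither adding a halogen to the phenyl nor changing where it sits separates one compound from another. No measurement shown here accounts for this flat result.

The compounds shown carry only a plain or singly halogenated phenyl at this place, so it remains open whether an amine, a carboxylic acid or a methoxy group on that phenyl, or a longer alkyl chain in place of the whole phenyl, would move the number beyond the scatter. On these data alone, since the shared core and its chain are the same in all four compounds, the part they play in this read-out also remains open.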